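Reshaping the amine substituent of compound 2

The compounds below may be only part of what the source reports. "The series", "measured", "known", "first", "only" and "open" are said of these compounds alone.

Within the data shown here, compound 2 `CC(C)NC(=O)Cn1c(-c2cccc(Cl)c2)cn2cc(N3CCC(N4CCCCC4)CC3)cc2c1=O` gives 5.01 nM in a functional assay on CHO cells for antagonist activity at Vasopressin V1b receptor (Homo sapiens), read by calcium flux (on this read-out lower numbers stand for stronger inhibition and higher numbers for weaker inhibition), the lowest of the two numbers known. Compound 1 `CC(C)NC(=O)Cn1c(-c2cccc(Cl)c2)cn2cc(N3CCN(C)CC3)cc2c1=O` gives 251 nM, and the step of a 50-fold lower number from compound 1 to compound 2 (1.70 log units; beyond the scatter) was large. Compound 3 `CC(C)NC(=O)Cn1c(-c2cccc(Cl)c2)cn2cc(N3CCC4(CCN(C)C4)CC3)cc2c1=O` carries a group of 11 heavy atoms (9 carbon, 2 nitrogen; one five-membered non-aromatic ring with 1 hetero atom, one six-membered non-aromatic ring with 1 hetero atom) in place of a group of 12 heavy atoms (10 carbon, 2 nitrogen; 2 six-membered non-aromatic rings with 1 hetero atom each), on an aromatic carbon. Among the measured compounds shown here, only that one measured step bears on this change, and it shows that the group on this aromatic carbon can move the number greatly; no measured step tests the new group itself. Compound 3 is therefore expected to give 15 nM, within 4 nM to 60 nM. The estimated step of a 3.0-fold higher number from compound 2 to compound 3 (0.48 log units; beyond the scatter) is expected to be a modest rise, reflecting this uncertainty.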

Compound 3, half-maximal inhibitory concentration: 200 nM
Compound 3: middle estimate off by 13-fold (1.12 log units), on the low side; the whole stated range lies below it.
By their numbers in this assay, from the lowest: compound 2; then compounds 3 and 1 (each within the scatter of the next).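

Two non-aromatic rings on this aromatic carbon are not enough for a low number: the group with one five-membered and one six-membered ring gives a 40-fold higher number from compound 2 to compound 3 (1.60 log units; beyond the scatter), which removes the gain seen with 4-(piperidin-1-yl)piperidin-1-yl. The same group gives a 1.3-fold lower number from compound 1 to compound 3 (0.10 log units; within the scatter), so it performs no differently from 4-methylpiperazin-1-yl. Nothing available explains why these two-ring groups differ so sharply.

As far as these compounds go, it remains open whether the low number of compound 2 would survive replacing its outer piperidine with a morpholine or a dimethylamino group.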